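This account rests on a few compounds, and the source may have more. Where it says the series, first, only, none or still open, it means among the compounds named here.

Compound 2 `Cc1nc(N2CCC(N3CCNC3=O)CC2)nc2ccc(NC(=O)/C=C/c3ccc(OC(F)(F)F)cc3)cc12` stands level with compound 1 `Cc1nc(N2CCC(N3CCOC3=O)CC2)nc2ccc(NC(=O)/C=C/c3ccc(OC(F)(F)F)cc3)cc12` in a functional assay on CHO-K1 cells for antagonist activity at melanin-concentrating hormone receptor 1 (Homo sapiens), read by inositol phosphate accumulation, with stated times of 10 min and 45 min; a higher number here means a weaker inhibitor, a lower number a stronger inhibitor: compound 2 gives 31 nM, and compound 1 gives 31 nM, together the lowest of the three numbers measured. Compound 3 `Cc1nc(NCCNS(C)(=O)=O)nc2ccc(NC(=O)/C=C/c3ccc(OC(F)(F)F)cc3)cc12` gives 142 nM, and the step of a 4.6-fold higher number from compound 2 to compound 3 (0.66 log units; beyond the scatter) is the furthest that compound 2 stands from any measured neighbour. Compound 4 `Cc1nc(N2CCC(N3CCN(C)C3=O)CC2)nc2ccc(NC(=O)/C=C/c3ccc(OC(F)(F)F)cc3)cc12` is not yet measured. It differs from compound 2 by methyl in place of hydrogen on an amide-type nitrogen in a ring, the 2-oxoimidazolidin-1-yl becoming 3-methyl-2-oxoimidazolidin-1-yl. Of the measured steps, the one that bears most on this is no change at the digits printed from compound 1 to compound 2 (within the scatter), which altered the five-membered ring without moving the number. The larger steps of a 4.6-fold higher number from compound 1 to compound 3 (0.66 log units; beyond the scatter) and a 4.6-fold higher number from compound 2 to compound 3 (0.66 log units; beyond the scatter) replaced the whole 4-(2-oxoimidazolidin-1-yl)piperidin-1-yl group and say little about a methyl on the ring nitrogen. A step of a 1.1-fold higher number from compound 2 to compound 4 (0.05 log units; within the scatter) is therefore expected, within the scatter. Compound 4 is expected to give 35 nM in this assay, in an estimated range of 15 nM to 90 nM.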

Compound 4, half-maximal inhibitory concentration: 21 nM
Estimate against measurement, compound 4: 1.7-fold (0.22 log units) above; the range from low to high includes it.
By their numbers in this assay, from the lowest: compounds 4, 1 and 2 (each within the scatter of the next); then compound 3.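

In this assay, methyl in place of hydrogen on the amide-type nitrogen in the ring gives a 1.5-fold lower number from compound 2 to compound 4 (0.17 log units; within the scatter) and so stays within the scatter, showing that this nitrogen can carry a small substituent without a measurable change in the number. The step of a 1.5-fold lower number from compound 1 to compound 4 (0.17 log units; within the scatter) likewise stays within the scatter, so 3-methyl-2-oxoimidazolidin-1-yl and 2-oxo-1,3-oxazolidin-3-yl cannot be told apart on the saturated ring carbon in this series. No supporting data are available to explain these results.

Methyl is the only group shown on this nitrogen, so it remains open whether an ethyl, a benzyl or a longer chain ending in a carboxylic acid or an amine would leave the number within the scatter. As far as these compounds go, how far this tolerance extends to other cores also remains open.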